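Swapping an ethylpiperazine for a thiadiazolylsulfanyl group

The source may hold more compounds than are shown below. What is called first, only, known or untested is meant among the compounds shown, and "the series" means these compounds.

Measured compounds:
- compound 1 `CCN1CCN(c2cc(C(F)(F)F)nc(SCc3ccc(C(F)(F)F)cc3)n2)CC1`: 27200 nM
- compound 2 `FC(F)(F)c1ccc(CSc2nc(N3CCN(c4ncccn4)CC3)cc(C(F)(F)F)n2)cc1`: > 50000 nM

Going by the values given here, in a functional assay on PC-3 cells (Homo sapiens) for inhibition, read by MTT assay, with a stated time of 72 h (on this read-out lower numbers stand for stronger inhibition and higher numbers for weaker inhibition), compound 1 gives 27200 nM, the only actual number among the values shown. Compound 2 reaches only (the limit of > 50000 nM in this assay, at which 1 of the 2 values shown sits), which is a limit of the assay rather than a number. Among the compounds with values here, the one measured step, an at least 1.8-fold higher number from compound 1 to compound 2 (0.26 log units; that floor lies within the scatter), goes toward weaker inhibition, and its floor lies within the scatter.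

Compound 3 `Cc1nnc(Sc2cc(C(F)(F)F)nc(SCc3ccc(C(F)(F)F)cc3)n2)s1` differs from compound 1 by (5-methyl-1,3,4-thiadiazol-2-yl)sulfanyl in place of 4-ethylpiperazin-1-yl on an aromatic carbon. The measured step concerns a change on the amine nitrogen of the piperazine ring, whereas here the whole 4-ethylpiperazin-1-yl group leaves and a (5-methyl-1,3,4-thiadiazol-2-yl)sulfanyl group enters on an aromatic carbon of the shared core. Within the data shown here, no measured step bears directly on this change, so the expectation rests on the weak activity of compound 1 at 27200 nM and carries wide uncertainty.

Compound 3 is therefore expected to give 30000 nM, with a range from 8000 nM to 110000 nM. The expected step of a 1.1-fold higher number from compound 1 to compound 3 (0.04 log units; within the scatter) stays within the scatter.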

Compound 3, half-maximal inhibitory concentration: > 50000 nM
Compound 3: only a limit was reported; the forecaster's own chance of this, stated with the estimate: 35%; middle value at least 1.6-fold (0.22 log units) from the limit.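

Placing (5-methyl-1,3,4-thiadiazol-2-yl)sulfanyl on this aromatic carbon of the shared core in place of 4-ethylpiperazin-1-yl gives, in this assay, an at least 1.8-fold higher number from compound 1 to compound 3 (0.26 log units; that floor lies within the scatter). The earlier step changed only the group on the amine nitrogen and kept the piperazine ring, whereas this one removes that ring and puts a five-membered aromatic ring in its place, and still no stronger inhibition appears. Because the result for compound 3 is a limit and not a number, the true size of the step cannot be read, and the floor alone does not separate it from the scatter: the limit of > 50000 nM in this assay, at which 2 of the 3 values shown sit.

The compounds shown leave open whether any group at this position can give inhibition clearly stronger than that of compound 1, for example a morpholine ring, a simple dimethylamino group or a piperazine with a free amine nitrogen. They also leave open whether a thiadiazole joined directly to the shared core, without the sulfur atom, or one carrying a primary amine instead of the methyl group, would behave any differently.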